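Small Heteroaryl Amides on a Shared Quinoline Core

A few compounds are considered here, and "the series" means these few. Any claim that something is new, unique, unknown or untested is made for them only; others in the source may bear on it.

Compound 1 `CC(=O)Nc1cccc2c(-c3cccc(NC(=O)c4ccc(Cl)cc4C(F)(F)F)c3)ccnc12` gives > 20000 nM in a functional assay on A375P cells (Homo sapiens) for antiproliferative activity, read by MTT assay, with a stated time of 48 h (on this read-out lower numbers stand for stronger inhibition and higher numbers for weaker inhibition), a limit. Compound 2 `CC(=O)Nc1cccc2c(-c3cccc(NC(=O)c4cc(Cl)cc(C(F)(F)F)c4)c3)ccnc12` gives 6200 nM in this assay. Compound 3 `CC(=O)Nc1cccc2c(-c3cccc(NC(=O)c4cc(C)oc4C)c3)ccnc12` gives > 20000 nM in this assay, again a limit.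

Compound 3 thus sits at the limit of > 20000 nM in this assay, at which 2 of the 3 values shown sit, where no number is read. Compound 4 `CC(=O)Nc1cccc2c(-c3cccc(NC(=O)c4nccs4)c3)ccnc12` differs by 1,3-thiazol-2-yl in place of 2,5-dimethylfuran-3-yl on a carbonyl carbon. The step of an at least 3.2-fold higher number from compound 2 to compound 3 (0.50 log units; beyond the scatter) shows that moving to the dimethylfuran lost activity; the step that the two limits leave unreadable from compound 1 to compound 3 cannot be sized. For the measured compounds named here, the thiazolyl amide brings no measured precedent, and the limit on compound 3 leaves little room to read a direction. Compound 4 is therefore expected near the same limit, a step that the limit leaves unreadable from compound 3 to compound 4. The estimated value for compound 4 is 25000 nM, spanning 6000 nM to 100000 nM.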

Compound 4, half-maximal inhibitory concentration: > 20000 nM
Compound 4 ended at the assay's limit; the forecaster's own chance of this, stated with the estimate: 65%; the middle value does not contradict the limit.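

With 1,3-thiazol-2-yl on the carbonyl carbon, the read-out shows an at least 3.2-fold higher number from compound 2 to compound 4 (0.50 log units; beyond the scatter), so a second five-membered aromatic ring, this one with 2 hetero atoms, also falls short of the 3-chloro-5-(trifluoromethyl)phenyl amide. The steps to compound 4 from compound 1 and from compound 3 cannot be read, as both ends are limits. Among these amides, only compound 2 gives a number in this assay, and the rest share one limit: the limit of > 20000 nM in this assay, at which 3 of the 4 values shown sit.

From the compounds shown here alone, whether any five-membered ring here can give a readable value stays open. So does what a phenyl ring carrying an amine or a carboxylic acid would give in this place.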